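The compounds below may be only part of what the source reports. "The series", "measured", "known", "first", "only" and "open" are said of these compounds alone.

Compound 1 `CCN(Cc1ccc(OCCN2C(=O)CCC2=O)c(C)c1)C(CC(=O)O)c1ccc(Cl)cc1`: 100%
Compound 2 `Cc1cc(CN(CC2CC2)[C@@H](CC(=O)O)c2ccc(Cl)cc2)ccc1OCCN1C(=O)CCC1=O`: 90%

In an ADME assay on liver (Homo sapiens) for metabolic stability, read by LC-MS, using microsomes and NADPH (a higher number here means that more of the compound is left, a lower number that less of the compound is left), compound 1 gives 100%, the higher of the two numbers recorded. Compound 2 gives 90% in this assay, a value that sits within the scatter of compound 1, so the two cannot be told apart on these numbers. The account now turns to compound 3 `CCCCN(Cc1ccc(OCCN2C(=O)CCC2=O)c(C)c1)C(CC(=O)O)c1ccc(Cl)cc1`, which has not yet been measured in this assay. Compound 3 differs from compound 1 in one place: ethyl in place of hydrogen on a saturated chain carbon, two bonds along the chain from an amine nitrogen. Going by the values given here, no step between two measured compounds matches this change, so there is no measured precedent to draw on. The step is expected to be small and, if anything, downward, with a number 15 percentage points lower from compound 1 to compound 3 (beyond the scatter) as the expected size. Compound 3 is estimated at 85%, with a range from 60% to 100%.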

Compound 3, percent of the compound remaining: 83%
Beside the measured number, compound 3's estimate is 2 percentage points above it; measured number inside the range.
By their numbers in this assay, from the lowest: compounds 3, 2 and 1 (each within the scatter of the next, the first and the last beyond it).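

Going by these compounds alone, this is the first step that can be read at one place: with ethyl in place of hydrogen on a saturated chain carbon, two bonds along the chain from an amine nitrogen, this assay gives a number 17 percentage points lower from compound 1 to compound 3 (beyond the scatter). Within the data shown here, the step is modest, yet it lies beyond the scatter, which the earlier compounds, with no single-place step between them, could not show. This carbon therefore tolerates ethyl with a measurable loss in the compound remaining, though compound 3 still keeps 83%. No measurement at hand bears on why the number falls.

From the compounds shown here alone, whether methyl, propyl or a longer chain on the same carbon would give a smaller or larger step stays open. So does whether ethyl would give a step of this size with the cyclopropylmethyl group of compound 2 on the amine nitrogen.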